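Clearance after replacing cyclohexyl with pyridin-3-yl

The compounds below may be only part of what the source reports. "The series", "measured", "known", "first", "only" and "open" are said of these compounds alone.

In an ADME assay (liver) for metabolic stability, with Liver microsome (Rattus norvegicus) as the target, using microsomes and NADPH, with a stated time of 30 min, at 37 degrees C, tested at 1 uM (on this read-out higher numbers stand for fast clearance and lower numbers for slow clearance), compound 1 (`CC(O)(c1ccc(-c2ccc(S(=O)(=O)c3ccc(N)nc3)cn2)nc1)C(F)(F)F`) gives < 14 mL.min-1.g-1, which is a limit of the assay and not a number. Compound 2 (`CCNc1nc(S(=O)(=O)c2ccc(N)nc2)ccc1-c1ccc(C(C)(O)C(F)(F)F)cn1`) gives 42 mL.min-1.g-1. Compound 3 (`CC(O)(c1ccc(-c2ccc(S(=O)(=O)c3ccc(N)nc3)nc2NC2CCCCC2)nc1)C(F)(F)F`) gives 280 mL.min-1.g-1, the highest number in this small set. Compound 4 (`CC(O)(c1ccc(-c2ccc(S(=O)(=O)c3ccc(N)nc3)nc2Nc2cccnc2)nc1)C(F)(F)F`) has not yet been measured. It carries pyridin-3-yl in place of cyclohexyl on a nitrogen on an aromatic ring.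

Within the data shown here, one measured step bears on this change, with cyclohexyl in place of ethyl on that same kind of nitrogen. A fall of broadly similar size is expected because a 6.7-fold higher number from compound 2 to compound 3 (0.82 log units; beyond the scatter) was a modest rise that came with the cyclohexyl now leaving. Pyridin-3-yl played no part in that step, so this is only a rough guide, and the range has to stay wide. The expected change is a 3.5-fold lower number from compound 3 to compound 4 (0.54 log units; beyond the scatter). For compound 4 the estimate is 80 mL.min-1.g-1, with an expected range from 25 mL.min-1.g-1 to 220 mL.min-1.g-1.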

Compound 4, intrinsic clearance in microsomes: 142 mL.min-1.g-1
Compound 4: the middle estimate sits 1.8-fold (0.25 log units) below what was measured; low and high end bracket the measured number.
By their numbers in this assay, from the lowest: compound 2; then compounds 4 and 3 (each within the scatter of the next). At a limit, below all of these: compound 1.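

In this assay, putting the aromatic pyridin-3-yl ring on this nitrogen in place of the non-aromatic cyclohexyl ring gives a 2.0-fold lower number from compound 3 to compound 4 (0.29 log units; within the scatter), so the two rings cannot be told apart here. Among these compounds, the change from ethyl to pyridin-3-yl gives a 3.4-fold higher number from compound 2 to compound 4 (0.53 log units; beyond the scatter), which places this aromatic ring on the same side of ethyl as cyclohexyl, where the earlier compounds showed only cyclohexyl. Across compounds 2, 3 and 4, the clear difference therefore lies between ethyl and a ring, not between one ring and the other, though these numbers cannot say why.

From the compounds shown here alone, whether a methyl group or a small cyclopropyl ring on this nitrogen would give a number nearer that of compound 2 remains open. Compound 1 gives no number for a comparison, only a limit of the assay: the limit of < 14 mL.min-1.g-1 in this assay, at which 1 of the 4 values shown sits.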